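The compounds below may be only part of what the source reports. "The series", "measured", "known", "first", "only" and "open" are said of these compounds alone.

Measured so far in an ADME assay on L6 cells (Rattus norvegicus) for cytotoxicity, read by resazurin assay, with a stated time of 72 h; a lower number here means a stronger inhibitor, a higher number a weaker inhibitor

Compound 1 `OC(c1ccc(Cl)cc1)(c1ccc(Cl)cc1)c1cncnc1` gives 47200 nM
Compound 2 `OC(c1ccc(Cl)cc1)(c1ccc(Br)cc1)c1cncnc1` gives 58700 nM
Compound 3 `OC(c1ccc(Cl)cc1)(c1ccc(C(F)(F)F)cc1)c1cncnc1` gives 66800 nM

Compound 3 stands with the other two, and nothing sets it apart beyond the scatter. The steps reaching it are a 1.4-fold higher number from compound 1 to compound 3 (0.15 log units; within the scatter) and a 1.1-fold higher number from compound 2 to compound 3 (0.06 log units; within the scatter), and the remaining one is a 1.2-fold higher number from compound 1 to compound 2 (0.09 log units; within the scatter). The change leading to compound 4 `OC(c1ccc(Cl)cc1)(c1ccc(C(F)(F)F)cc1)c1cccnc1` is pyridin-3-yl in place of pyrimidin-5-yl on a saturated chain carbon bound to two aromatic carbons and an oxygen on a saturated carbon, counted as pyridin-3-yl in place of pyrimidin-5-yl on a saturated chain carbon bound to two aromatic carbons and an oxygen on a saturated carbon. Going by the values given here, no measured step makes this exchange, so those small steps guide it only weakly. A modest move to a lower number is expected, estimated as a 1.7-fold lower number from compound 3 to compound 4 (0.22 log units; within the scatter). For compound 4 the estimate is 40000 nM, with an expected range from 13000 nM to 90000 nM.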

Compound 4, half-maximal inhibitory concentration: 56400 nM
Compound 4: the middle estimate sits 1.4-fold (0.15 log units) below what was measured; the measured number falls inside the stated range.
By their numbers in this assay, from the lowest: compounds 1, 4, 2 and 3 (each within the scatter of the next).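

In this assay, the steps among compounds 1 to 3 changed only an aromatic substituent, whereas this one changes the ring on the saturated chain carbon bound to two aromatic carbons and an oxygen on a saturated carbon, giving a 1.2-fold lower number from compound 3 to compound 4 (0.07 log units; within the scatter). This single exchange of pyrimidin-5-yl for pyridin-3-yl therefore leaves the number within the scatter. Nothing available explains this result. As far as these compounds go, it remains open whether an amine or a carboxylic acid at this place would move the number beyond the scatter. From the compounds shown here alone, it also remains open whether the same ring exchange would behave alike with the bromo or dichloro compounds.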